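The compounds below may be only part of what the source reports. "The series", "measured", "known", "first", "only" and "open" are said of these compounds alone.

Three compounds have been measured in a functional assay on HeLa cells (Homo sapiens) for cytotoxicity, read by MTT assay, with a stated time of 72 h; on this read-out higher numbers stand for weaker inhibition and lower numbers for stronger inhibition:

compound 1, `CC(=O)O[C@@H]1/C=C/C(C)=C/C[C@H](O)/C=C/C(C)=C/[C@@H](NC(=O)[C@H](C)O)[C@]2(C)C(=O)O[C@H](C1)[C@@H](C)C2=O`, gives 48200 nM
compound 2, `CC1=C\C[C@H](O)/C=C/C(C)=C/[C@@H](NC(=O)[C@H](C)O)[C@H](C)C(=O)/C(C)=C/C[C@H](O)\C=C\1`, gives 13300 nM
compound 3, `CC1=C\C[C@H](O)/C=C/C(C)=C/[C@@H](NC(=O)[C@H](C)O)[C@@H](C)C(=O)/C(C)=C/C[C@H](O)\C=C\1`, gives 45400 nM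

Compound 2 stands at the lowest number of the three. Its nearest neighbour is compound 3, reached by a 3.4-fold higher number from compound 2 to compound 3 (0.53 log units; beyond the scatter); compound 1 sits further away still, its value standing higher than that of compound 2 and close to that of compound 3.

Compound 4, `CC(=O)C(=O)N[C@@H]1/C=C(C)/C=C/[C@@H](O)C/C=C(C)/C=C/[C@@H](O)C/C=C(\C)C(=O)[C@H]1C`, has not yet been measured. It differs from compound 2 in one place: acetyl in place of 1-hydroxyethyl on a carbonyl carbon. Among the measured compounds shown here, the only measured step, a 3.4-fold higher number from compound 2 to compound 3 (0.53 log units; beyond the scatter), rests on the fact that compounds 2 and 3 differ only in the configuration as drawn and so concerns a single stereocentre on the ring, not the side chain on the amide nitrogen; no measured step touches the group that changes here. With nothing to guide the direction, the expectation for compound 4 is that it remains close to compound 2, and the step of a 1.1-fold higher number from compound 2 to compound 4 (0.05 log units; within the scatter) is expected to stay within the scatter. Compound 4 is accordingly estimated at 15000 nM, with a range from 5000 nM to 45000 nM.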

Compound 4, half-maximal inhibitory concentration: 72900 nM
The estimate for compound 4 lay 4.9-fold (0.69 log units) below the measured number; measured number above the stated range.
By their numbers in this assay, from the lowest: compound 2; then compounds 3, 1 and 4 (each within the scatter of the next).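

In this assay, among the compounds shown here, putting acetyl in place of 1-hydroxyethyl on the carbonyl carbon gives a 5.5-fold higher number from compound 2 to compound 4 (0.74 log units; beyond the scatter), so the side chain on the amide nitrogen, which no earlier step touched, turns out to be a place where the number responds. The exchange keeps the count of heavy atoms and the single hydrogen-bond acceptor of the group; what it alters is the loss of the hydrogen-bond donor and the defined stereocentre and the gain of a double bond outside aromatic rings. Together with a 3.4-fold higher number from compound 2 to compound 3 (0.53 log units; beyond the scatter), this makes two single changes away from compound 2, one in configuration on the ring and one in the side chain, and both lead to a higher number.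

Nothing on hand bears on why this exchange raises the number. Still open, on these data alone, is which of the altered features carries the step, and how the number would respond to a plain ethyl or a 1-aminoethyl group on that same carbonyl carbon.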